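Cyclohexylamino to Dimethylamino: Solubility at Low pH

The source may report more compounds than this note shows. Statements on the series, on what has been measured and on what is new or still open speak of the compounds shown alone.

Compound 1 `CC(C)Nc1nc(NCc2ccco2)c2ccccc2n1` gives >= 30000 nM in a physicochemical assay for solubility, at pH 2 (a higher number here means a more soluble compound, a lower number a less soluble compound), a limit of the assay.
Compound 2 `CCOC(=O)CNc1nc(NC(C)C)nc2ccccc12` gives >= 30000 nM in this assay, a limit of the assay.
Compound 3 `CC(C)Nc1nc(NC2CCCCC2)c2ccccc2n1` gives >= 30000 nM in this assay, a limit of the assay.

Compound 3 therefore stands only at a limit, as do the two other measured compounds: the limit of >= 30000 nM in this assay, at which 3 of the 3 values shown sit. Every comparison among them is consequently blank: a step that the two limits leave unreadable from compound 1 to compound 2; a step that the two limits leave unreadable from compound 1 to compound 3; a step that the two limits leave unreadable from compound 2 to compound 3. Going by the values given here, none of these steps can say how much a change at the amino group alters solubility, only that each compound reaches the limit.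

Compound 4 `CC(C)Nc1nc(N(C)C)c2ccccc2n1` differs from compound 3 in one place: dimethylamino in place of cyclohexylamino on an aromatic carbon. Among the compounds with values here, since the three measured steps bear on the same position but are all unreadable, they give no size and no direction for the step from compound 3 to compound 4, only the observation that three different groups there all left the compound at the limit. Compound 4 is therefore expected to sit at the limit too, with an expected step of a number no higher from compound 3 to compound 4 (the limit leaves the size open). The estimate for compound 4 in this assay is 30000 nM, within 10000 nM to 100000 nM.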

Compound 4, solubility: >= 30000 nM
Compound 4 gave a limit, no number; the forecaster's own chance of this, stated with the estimate: 80%; the middle value lies on the limit itself.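

Compound 4 also gives a limit of the assay rather than a number, so its steps from compound 1, compound 2 and compound 3 cannot be read: the limit of >= 30000 nM in this assay, at which 4 of the 4 values shown sit.

The compounds shown leave open how far solubility in this assay truly differs among these four compounds, if it differs at all.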